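Methoxy to hydroxy on a pyrazole urea series

The source may hold more compounds than are shown below. What is called first, only, known or untested is meant among the compounds shown, and "the series" means these compounds.

Measured compounds:
Compound 1 `COc1cc(-c2nn(-c3cccc(NC(=O)Nc4cc(C(F)(F)F)cc(C(F)(F)F)c4)c3)cc2-c2ccncc2)ccc1Cl` gives 1990 nM in a functional assay on MDA-MB-435 cells (Homo sapiens) for inhibition, read by sulforhodamine B assay, with a stated time of 48 h; a higher number here means a weaker inhibitor of growth, a lower number a stronger inhibitor of growth.
Compound 2 `O=C(Nc1cccc(-n2cc(-c3ccncc3)c(-c3ccc(Cl)c(O)c3)n2)c1)Nc1cc(C(F)(F)F)cc(C(F)(F)F)c1` gives 2590 nM in this assay.
Compound 3 `COc1cc(-c2nn(-c3cccc(NC(=O)Nc4ccc(Cl)c(C(F)(F)F)c4)c3)cc2-c2ccncc2)ccc1Cl` gives 1690 nM in this assay.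

Compound 4 `O=C(Nc1cccc(-n2cc(-c3ccncc3)c(-c3ccc(Cl)c(O)c3)n2)c1)Nc1ccc(Cl)c(C(F)(F)F)c1` has not yet been measured. The change from compound 1 to compound 2 is hydrogen in place of methyl on an oxygen on an aromatic ring, and it made a step of a 1.3-fold higher number from compound 1 to compound 2 (0.11 log units; within the scatter). The change from compound 3 to compound 4 is hydrogen in place of methyl on an oxygen on an aromatic ring, the same change at the same place. The difference between the core of compound 1 and the core of compound 3 is not broken down here; their two values in this assay lie close together.

For the measured compounds named here, compound 4 is therefore expected to follow the earlier step, with an estimated 1.3-fold higher number from compound 3 to compound 4 (0.11 log units; within the scatter), because the only measured instance of this change gave a 1.3-fold higher number from compound 1 to compound 2 (0.11 log units; within the scatter). On that basis compound 4 is estimated at 2200 nM, with a likely range of 1100 nM to 4400 nM.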

Compound 4, concentration for total growth inhibition: 1770 nM
Beside the measured number, compound 4's estimate is 1.2-fold (0.09 log units) above it, within the range that was stated.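

On the core of compound 3, replacing methoxy with hydroxy gave a 1.0-fold higher number from compound 3 to compound 4 (0.02 log units; within the scatter) in this assay. Set beside the earlier step, the change carried across the two cores with no difference that can be told from the scatter: the same change on two cores in this assay, a 1.3-fold higher number (0.11 log units; within the scatter) from compound 1 to compound 2 and a 1.0-fold higher number (0.02 log units; within the scatter) from compound 3 to compound 4, 1.2-fold (0.09 log units) apart, within the scatter of two such steps. For the compounds shown here, both steps lie within the scatter, so this shows only that the change left the number essentially unmoved on these two cores, and it does not show how the change would behave on any other core.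

The compounds shown leave open whether an amine or an ethoxy group in place of the hydroxy would give a step beyond the scatter. They also leave open whether the same change would stay as small on a core carrying a carboxylic acid in place of the trifluoromethyl groups.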